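Ethynyl in Place of Hydrogen: Estimating Compound 4

A few compounds are considered here, and "the series" means these few. Any claim that something is new, unique, unknown or untested is made for them only; others in the source may bear on it.

Of the compounds shown here, three have so far been measured in a functional assay on WIL2 cells (Homo sapiens) for inhibition; a lower number here means a stronger inhibitor, a higher number a weaker inhibitor. Compound 1 `Cc1nc(O)c2cc(CN(C)c3ccc(C(=O)N[C@@H](CCC(=O)O)C(=O)N(C)[C@@H](CCC(=O)O)C(=O)O)c(F)c3)ccc2n1` gives 2300 nM. Compound 3 `Cc1nc(O)c2cc(CN(C)c3ccc(C(=O)N[C@@H](CCC(=O)O)C(=O)N(C)[C@@H](CCC(=O)O)C(=O)O)cc3)c(C)cc2n1` gives 800 nM in this assay, and compound 2 `C#CCN(Cc1cc2c(O)nc(C)nc2cc1C)c1ccc(C(=O)N[C@@H](CCC(=O)O)C(=O)N(C)[C@@H](CCC(=O)O)C(=O)O)cc1` gives 640 nM. Compound 1 stands highest of the three numbers, beyond the scatter from both of the others; the difference between its core and the core of compound 3 is not broken down here.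

Compounds 3 and 2 differ in a single place: ethynyl in place of hydrogen on a saturated chain carbon bound to a nitrogen on an aromatic ring. That change made a 1.3-fold lower number from compound 3 to compound 2 (0.10 log units; within the scatter), a step that stays within the usual scatter.

Compound 4 `C#CCN(Cc1ccc2nc(C)nc(O)c2c1)c1ccc(C(=O)N[C@@H](CCC(=O)O)C(=O)N(C)[C@@H](CCC(=O)O)C(=O)O)c(F)c1` has not been measured in this assay. It differs from compound 1 by the same change, (ethynyl in place of hydrogen on a saturated chain carbon bound to a nitrogen on an aromatic ring), applied on the core of compound 1 rather than on that of compound 3.

Only one earlier instance of this change exists among these compounds. A step of similar size is expected, a 1.3-fold lower number from compound 1 to compound 4 (0.11 log units; within the scatter), because the earlier instance gave a 1.3-fold lower number from compound 3 to compound 2 (0.10 log units; within the scatter). Compound 4 is accordingly estimated at 1800 nM, with the expected range running from 700 nM to 4500 nM.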

Compound 4, half-maximal inhibitory concentration: 440 nM
Compound 4: the middle estimate sits 4.1-fold (0.61 log units) above what was measured, and the stated range ends above it.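

In this assay, putting ethynyl in place of hydrogen on a saturated chain carbon bound to a nitrogen on an aromatic ring gave a 5.2-fold lower number from compound 1 to compound 4 (0.72 log units; beyond the scatter), a step beyond the scatter, whereas the same change on the core of compound 3 gave a 1.3-fold lower number from compound 3 to compound 2 (0.10 log units; within the scatter), a step within it. The size of the step therefore did not carry over from one core to the other, and the two instances differ: the same change on two cores in this assay, a 1.3-fold lower number (0.10 log units; within the scatter) from compound 3 to compound 2 and a 5.2-fold lower number (0.72 log units; beyond the scatter) from compound 1 to compound 4, 4.2-fold (0.62 log units) apart, beyond the scatter of two such steps. For the compounds shown here, this shows that, in this series, a step read on one core is a poor guide to the size of the step on another, but with only two pairs it does not show which difference between the cores goes with the larger step.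

Still open, on these data alone, is how a different group at the same place, such as a vinyl or a nitrile, would compare with ethynyl on these two cores. As far as these compounds go, it is also open whether the step on a further core would resemble the one on the core of compound 1 or the one on the core of compound 3.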